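The source may report more compounds than this note shows. Statements on the series, on what has been measured and on what is new or still open speak of the compounds shown alone.

Two compounds of a shared core were tested in a functional assay on THP-1 cells (Homo sapiens) for antiproliferative activity, tested at 100 uM; a higher number here means a stronger effect of the compound at the concentration tested, a lower number a weaker effect. Compound 1 `Cc1cc2cc(NC(=O)c3ccc(S(=O)(=O)Nc4ccc5c(c4)cc(C)c(=O)n5C)cc3)ccc2n(C)c1=O` gives 73% in this assay. Compound 2 `Cc1cc2cc(NS(=O)(=O)Cc3ccc(C(=O)NO)cc3)ccc2n(C)c1=O` reaches 89% in this assay, the higher of the two numbers, and stands above compound 1 by a margin beyond the usual scatter.

The next compound, compound 3 `COC(=O)c1ccc(CS(=O)(=O)Nc2ccc3c(c2)cc(C)c(=O)n3C)cc1`, differs from compound 2 in one place: methoxy in place of hydroxyamino on a carbonyl carbon. No step between two measured compounds tracks this change, so its effect has no precedent among the compounds shown. Given that compound 2 gives 89% and that the hydroxyamino group is replaced, a fall in this assay is expected rather than a gain, though the size is uncertain; the step expected is a number 44 percentage points lower from compound 2 to compound 3 (beyond the scatter), downward and beyond the scatter.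

Compound 3 is therefore estimated to give 45% in this assay, within a range from 15% to 80%.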

Compound 3, a percentage reported as inhibition, at one concentration (the size of the read-out at that concentration, not a potency): 93%
Beside the measured number, compound 3's estimate is 48 percentage points below it; the whole stated range lies below it.
By their numbers in this assay, from the lowest: compound 1; then compounds 2 and 3 (each within the scatter of the next).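

Putting methoxy in place of hydroxyamino on a carbonyl carbon gives a number 4 percentage points higher from compound 2 to compound 3 (within the scatter) in this assay, so the change leaves this read-out unmoved. The hydroxycarbamoyl group is therefore not needed at this position for the effect seen here: methoxycarbonyl, which has none of the hydrogen-bond donors of the group it replaces, serves as well in this pair. Among the compounds shown here, as this read-out comes from a single concentration and is not a potency, the pair shows only that the two compounds match at that concentration. Nothing shown here accounts for this match. Still open, on these data alone, is whether a carboxylic acid or a simple amide on the same carbonyl carbon would also keep the effect, and whether compound 2 and compound 3 would still match at lower concentrations.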